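Swapping a pyridine for a pyrazine on the shared core

This account rests on a few compounds, and the source may have more. Where it says the series, first, only, none or still open, it means among the compounds named here.

Of the compounds shown here, two built on the same shared core have been measured in a functional assay on CHO-K1 cells for antagonist activity at adenosine receptor A1 (Homo sapiens), read by a beta-galactosidase reporter and cAMP accumulation, with stated times of 15 min and 6 h; a higher number here means a weaker inhibitor, a lower number a stronger inhibitor. Compound 1 `N#Cc1cccc(-c2nc(N)c3cc(Cc4ccccc4)sc3n2)c1` carries a 3-cyanophenyl group and gives 222 nM. Within the data shown here, compound 2 `Nc1nc(-c2ccccn2)nc2sc(Cc3ccccc3)cc12` carries a pyridin-2-yl group instead, and in this assay compound 2 gives 3710 nM, the highest of the two numbers; the single measured step, a 17-fold higher number from compound 1 to compound 2 (1.22 log units; beyond the scatter), shows how strongly this position responds to a change. Compound 3 `Nc1nc(-c2cnccn2)nc2sc(Cc3ccccc3)cc12` is not yet measured; it differs from compound 2 by pyrazin-2-yl in place of pyridin-2-yl on an aromatic carbon. Among the measured compounds shown here, no measured step covers this exact exchange, so the only guidance is that the same position moved the number far in the step from compound 1 to compound 2. For compound 3 a modest change is expected, a 1.3-fold higher number from compound 2 to compound 3 (0.13 log units; within the scatter), with the number estimated at 5000 nM and a range from 1500 nM to 16000 nM.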

Compound 3, inhibition constant: 91 nM
For compound 3 the middle estimate is 55-fold (1.74 log units) above the measured one, outside the stated range (below it).
By their numbers in this assay, from the lowest: compound 3; then compound 1; then compound 2.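

In this assay, the change from pyridin-2-yl to pyrazin-2-yl keeps the heavy-atom count the same and replaces one ring carbon with nitrogen, yet it gives a 41-fold lower number from compound 2 to compound 3 (1.61 log units; beyond the scatter) and is far from a neutral exchange. Compound 2 had suggested that a nitrogen-containing ring here might do worse than 3-cyanophenyl, but pyrazin-2-yl gives a 2.4-fold lower number from compound 1 to compound 3 (0.39 log units; beyond the scatter) and so ranks ahead of that group. No experimental information here explains why this small change has such a large effect.

The compounds shown leave open whether the gain is specific to pyrazin-2-yl or would also appear with another ring, such as pyrimidin-2-yl or pyridazin-3-yl. They also do not show whether a methyl group or an amine on the pyrazine ring would preserve this stronger inhibition.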